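A few compounds are considered here, and "the series" means these few. Any claim that something is new, unique, unknown or untested is made for them only; others in the source may bear on it.

Within the data shown here, compound 2 `CC(CN)C(C)(CN)C(=O)O` is the one compound here with a number: in an assay for inhibition of Ornithine decarboxylase (Rattus norvegicus) (a lower number here means a stronger inhibitor, a higher number a weaker inhibitor), compound 2 gives 1650000 nM. The other two values are limits of the assay. Compound 1 `CC(CN)(CCN)C(=O)O` reaches only the limit > 11000000 nM in this assay. Compound 3 `CC(C)(CN)CCN` likewise reaches only the limit > 10000000 nM in this assay. Compound 4 `CC(CN)C(C)(C)CN` is not yet measured; it differs from compound 2 by methyl in place of carboxy on a saturated chain carbon bound to three saturated chain carbons. The same change has been tried once, yet a step that the two limits leave unreadable from compound 1 to compound 3, so its size cannot be read. The other step, an at least 6.6-fold lower number from compound 1 to compound 2 (0.82 log units; beyond the scatter), concerns a different change. With little to go on, a weakening is expected, roughly a 3.0-fold higher number from compound 2 to compound 4 (0.48 log units; beyond the scatter), so compound 4 is estimated at 5000000 nM, between 1000000 nM and 25000000 nM.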

Compound 4, inhibition constant: > 10500000 nM
Compound 4 ended at the assay's limit; the forecaster's own chance of this, stated with the estimate: 40%; at least 2.1-fold (0.32 log units) between middle value and limit.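

In this assay, the carboxy on this saturated chain carbon bound to three saturated chain carbons now proves to matter: putting methyl in its place gives an at least 6.3-fold higher number from compound 2 to compound 4 (0.80 log units; beyond the scatter). Among these compounds, the earlier try of this change, from compound 1 to compound 3, joined two limits, and that step cannot be read, any more than the one from compound 3 to compound 4. Compound 4 reaches only a limit of the assay, so this size is a minimum: the limit of > 10500000 nM in this assay, at which 1 of the 4 values shown sits.

Open, going by these compounds, is whether an ester or an amide on this carbon would keep the activity of compound 2. Also open, on these data alone, is whether a longer chain carrying the carboxylic acid would do the same.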